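A few compounds are considered here, and "the series" means these few. Any claim that something is new, unique, unknown or untested is made for them only; others in the source may bear on it.

Of the compounds shown here, three have been measured in an ADME assay on NIH3T3 cells (Mus musculus) for cytotoxicity, read by MTT assay, with a stated time of 24 h; a lower number here means a stronger inhibitor, a higher number a weaker inhibitor. Compound 1 `O=C(CSc1nnnn1-c1ccccc1)N/N=c1/scc(-c2ccc(Br)cc2)n1-c1ccccc1` gives 433 ug/mL, the highest of the three numbers. Compound 2 `Cn1nnnc1SCC(=O)N/N=c1/scc(-c2ccc(Br)cc2)n1-c1ccccc1` gives 19.3 ug/mL and compound 3 `Cc1nnc(SCC(=O)N/N=c2/scc(-c3ccc(Br)cc3)n2-c2ccccc2)s1` gives 55 ug/mL. Every measured step alters the group carried on the sulfur: a 22-fold lower number from compound 1 to compound 2 (1.35 log units; beyond the scatter), a 7.9-fold lower number from compound 1 to compound 3 (0.90 log units; beyond the scatter) and a 2.8-fold higher number from compound 2 to compound 3 (0.45 log units; beyond the scatter). Compound 4 `N#Cc1ccc(-c2cs/c(=N/NC(=O)CSc3nnnn3-c3ccccc3)n2-c2ccccc2)cc1` keeps the group on the sulfur as in compound 1 and differs from it only on the six-membered aromatic ring of carbon only: cyano in place of bromo on an aromatic carbon. For the measured compounds named here, none of the measured steps touches that part of the molecule, so the measured compounds give no direct reading of the size or direction of this change. What is expected is therefore a step that stays within the scatter, a 1.1-fold lower number from compound 1 to compound 4 (0.03 log units; within the scatter), with a wide margin on either side to reflect the absence of a comparable step. On this basis compound 4 is estimated at 400 ug/mL, with a range from 150 ug/mL to 1000 ug/mL.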

Compound 4, half-maximal inhibitory concentration: 453 ug/mL
Compound 4: the middle estimate sits 1.1-fold (0.05 log units) below what was measured; measured number inside the range.
By their numbers in this assay, from the lowest: compound 2; then compound 3; then compounds 1 and 4 (each within the scatter of the next).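

In this assay this position gets its first reading, from the change of 4-bromophenyl to 4-cyanophenyl, with a 1.0-fold higher number from compound 1 to compound 4 (0.02 log units; within the scatter), so bromo and cyano cannot be told apart here while 1-phenyl-1H-tetrazol-5-yl stays on the sulfur. For the compounds shown here, the steps that alter the group on the sulfur all lie beyond the scatter, whereas this change on an aromatic carbon, para to a large group, is the only measured step that stays within it. No supporting data bear on why the two groups read alike.

From the compounds shown here alone, it remains open whether cyano and bromo also read alike with 1-methyl-1H-tetrazol-5-yl or 5-methyl-1,3,4-thiadiazol-2-yl on the sulfur, where the numbers are lower. Also open, going by these compounds, is whether an amine or a carboxylic acid at this position would move the number.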